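The compounds below may be only part of what the source reports. "The series", "measured", "known", "first", "only" and "open" are said of these compounds alone.

Compound 1, with the structure `CC(=O)N(C)C(C)C#CCn1ccnc1`, is the reference point of this set. In a functional assay on the whole organism for agonist activity, with Mus musculus as the target (a higher number here means that more compound is needed for the effect, a lower number that less compound is needed), compound 1 gives 2 mg/kg. Compound 2, with the structure `CC(=O)N(C)C(C)C#CCn1ccnc1C`, carries the change methyl in place of hydrogen on an aromatic carbon relative to compound 1. For compound 2 this assay does not return a number but only a limit, > 100 mg/kg. The step of an at least 50-fold higher number from compound 1 to compound 2 (1.69 log units; beyond the scatter) therefore rests on the limit of > 100 mg/kg in this assay, at which 1 of the 3 values shown sits, and is known only as a floor on the loss.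

Compound 3, with the structure `CN1CCN(CC#CCn2ccnc2)C1=O`, sits on a different core; how the core of compound 3 differs from the core of compound 1 is not broken down here. In this assay compound 3 gives 0.97 mg/kg, the lowest of the two numbers, with compound 1 nearest to it.

Compound 4, with the structure `Cc1cncn1CC#CCN1CCN(C)C1=O`, is not yet measured. It differs from compound 3 by methyl in place of hydrogen on an aromatic carbon. For the measured compounds named here, this is the same kind of change as the one from compound 1 to compound 2, but not the same: in compound 2 the methyl sits between two ring nitrogen atoms, whereas in compound 4 it sits next to the ring nitrogen and two ring bonds from the ring nitrogen, in both cases next to the ring atom that bears a large group. Because the measured step of an at least 50-fold higher number from compound 1 to compound 2 (1.69 log units; beyond the scatter) was large, a large loss is expected for compound 4 as well, tempered by the different place of the methyl. The expected step is a 31-fold higher number from compound 3 to compound 4 (1.49 log units; beyond the scatter). Compound 4 is estimated to give 30 mg/kg in this assay, expected to fall between 4 mg/kg and 150 mg/kg.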

Compound 4, dose for half-maximal effect: 2.5 mg/kg
Estimate against measurement, compound 4: 12-fold (1.08 log units) above; measured number outside the range, below it.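

In this assay the same replacement of hydrogen by methyl on an aromatic carbon gives only a 2.6-fold higher number from compound 3 to compound 4 (0.41 log units; beyond the scatter), so the size of its effect on the core of compound 1 does not carry over to the core of compound 3, although the number rises on both: the same change on two cores in this assay, an at least 50-fold higher number (1.69 log units; beyond the scatter) from compound 1 to compound 2 and a 2.6-fold higher number (0.41 log units; beyond the scatter) from compound 3 to compound 4, at least 19-fold (1.28 log units) apart, beyond the scatter of two such steps. Compound 2 stands at > 100 mg/kg, which is a limit of the assay and not a number, so the earlier step and the gap between the two steps are known only as floors: the limit of > 100 mg/kg in this assay, at which 1 of the 4 values shown sits. The pairs do not show whether the core or the place of the methyl accounts for the gap, since the methyl occupies a different ring carbon in compound 2 and compound 4, and core and place change together across these two steps.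

Going by these compounds, it stays open what the methyl does on the core of compound 1 at the ring carbon it occupies in compound 4, and on the core of compound 3 at the ring carbon it occupies in compound 2. Also open, on these data alone, is how an ethyl group or a chlorine atom at the place of the methyl in compound 4 would read in this assay.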